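This account rests on a few compounds, and the source may have more. Where it says the series, first, only, none or still open, it means among the compounds named here.

In an assay for inhibition of sodium- and chloride-dependent glycine transporter 1 (Homo sapiens) (a lower number here means that less compound is needed, a higher number that more compound is needed for the effect), the series of glycinamide benzhydryl amides is followed. Compound 1 `O=C(CNC(=O)c1ccc(Cl)cc1)NC(c1ccccc1)c1ccc(Cl)cc1` gives 150 nM; 300 nM; 280 nM (3 entries) in this assay; its repeated entries, (the several entries of compound 1 in this assay, 150 nM; 300 nM; 280 nM (3 entries)), show the spread that single numbers in this assay carry. Compound 2 `O=C(CNC(=O)c1ccc(F)cc1)NC(c1ccccc1)c1ccc(Cl)cc1` gives 88 nM; 88 nM (2 entries) in this assay. Within the data shown here, compound 3 `O=C(CNC(=O)c1ccc(F)cc1)NC(c1ccccc1)c1ccccc1`, the starting point of the step in question, gives 110 nM in this assay; this is the only number it has here, two further entries having produced no single number. On the numbers shown, compound 3 thus stands close to compound 2 and to compound 1.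

Compound 4 `COc1ccc(C(NC(=O)CNC(=O)c2ccc(F)cc2)c2ccccc2)cc1` differs from compound 3 by the change methoxy in place of hydrogen on an aromatic carbon. Among the measured compounds shown here, no measured pair in this set shares this change, so only the neighbourhood of compound 3 can guide the expectation. The step is expected to be small, a 1.4-fold higher number from compound 3 to compound 4 (0.13 log units; within the scatter), in either direction or none beyond the scatter. Compound 4 is therefore estimated at 150 nM in this assay, within a range from 50 nM to 450 nM.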

Compound 4, half-maximal effective concentration: 1100 nM
Estimate against measurement, compound 4: 7.3-fold (0.87 log units) below; measured number above the stated range.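

In this assay, the change from phenyl to 4-methoxyphenyl gives a 10-fold higher number from compound 3 to compound 4 (1.00 log units; beyond the scatter), which shows that the number can respond strongly to a substituent on this aromatic carbon, para to a large group. The earlier compounds shown here gave no sign of this: compound 3 gives 110 nM, and compound 2, with chloro at that place, gives 88 nM; 88 nM (2 entries). The step also has to be read against the spread of repeated entries, and it is larger than that spread: the several entries of compound 1 in this assay, 150 nM; 300 nM; 280 nM (3 entries)

The compounds shown leave open how a methyl, a hydroxy or an amine at this place would read, and so whether the step belongs to methoxy alone. They also leave open what lies behind the step, and whether methoxy would give a similar step on the other phenyl ring.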